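This account rests on a few compounds, and the source may have more. Where it says the series, first, only, none or still open, it means among the compounds named here.

Measured so far on this series:
compound 1, `O=[N+]([O-])c1ccc(CN2CCC(n3cc(CC(OCc4cc(-c5ccccc5)no4)c4ccc(Br)cc4)nn3)CC2)cc1`, 7000 nM
compound 2, `N#Cc1ccc(-c2cc(COC(Cc3cn(C4CCN(Cc5ccc([N+](=O)[O-])cc5)CC4)nn3)c3ccc(Br)cc3)on2)cc1`, 5000 nM

In a functional assay on Huh-7 cells (Homo sapiens) for cytotoxicity, with a stated time of 48 h (on this read-out lower numbers stand for stronger inhibition and higher numbers for weaker inhibition), compound 2 gives 5000 nM, the lowest of the two numbers measured; the nearest is compound 1 with 7000 nM, and the step of a 1.4-fold lower number from compound 1 to compound 2 (0.15 log units; within the scatter) lies within the scatter, so the two compounds cannot be told apart on this read-out.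

Compound 3, `O=[N+]([O-])c1ccc(CN2CCC(n3cc(CC(OCc4cc(-c5cccc(Br)c5)no4)c4ccc(Br)cc4)nn3)CC2)cc1`, is not yet measured. Against compound 2 it shows (3-bromophenyl in place of 4-cyanophenyl on an aromatic carbon). Among the measured compounds shown here, only one measured step touches this position: the step of a 1.4-fold lower number from compound 1 to compound 2 (0.15 log units; within the scatter), cyano in place of hydrogen on that aromatic carbon, and it stayed within the scatter. For the measured compounds named here, compound 3 undoes that cyano and brings in a 3-bromophenyl instead; the bromine part of the change has no measured counterpart. Going by the values given here, since the one comparable step showed nothing beyond the scatter, no step beyond the scatter is expected from compound 2 to compound 3 in this assay, that is a 1.2-fold higher number from compound 2 to compound 3 (0.08 log units; within the scatter). For compound 3 the expected value is 6000 nM, with a range from 2500 nM to 15000 nM.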

Compound 3, half-maximal inhibitory concentration: 3000 nM
For compound 3 the middle estimate is 2.0-fold (0.30 log units) above the measured one, and the stated range covers the measured number.
By their numbers in this assay, from the lowest: compounds 3, 2 and 1 (each within the scatter of the next, the first and the last beyond it).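

In this assay, among the compounds shown here, bromo in place of hydrogen on the phenyl group gives a 2.3-fold lower number from compound 1 to compound 3 (0.37 log units; beyond the scatter) and is so far the only step at this position beyond the scatter, though a modest one. The exchange of 4-cyanophenyl for 3-bromophenyl on the aromatic carbon next to the ring nitrogen gives a 1.7-fold lower number from compound 2 to compound 3 (0.22 log units; within the scatter) and stays within the scatter, so these two groups cannot be told apart on this read-out, and only compound 1 and compound 3 separate. Nothing at hand bears on the reason for this small separation.

Compound 2 and compound 3 differ in both the substituent and where it sits on the phenyl ring, so the compounds shown leave open whether the bromine itself or its placement matters, a question that a 4-bromophenyl or a 3-cyanophenyl group would address. Also open, from the compounds shown here alone, is whether a phenyl group bearing an amine or a carboxylic acid on this carbon would move the number further than these modest steps.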